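This account rests on a few compounds, and the source may have more. Where it says the series, first, only, none or still open, it means among the compounds named here.

Three compounds sharing one core were tested in a functional assay on CHO cells for agonist activity at prostaglandin E2 receptor EP4 subtype (Rattus norvegicus), read by cAMP accumulation and immunoassay, with a stated time of 10 min; on this read-out higher numbers stand for an effect only at larger amounts of compound and lower numbers for an effect already at smaller amounts. Compound 1 `Cc1cccc(C[C@H](O)/C=C/[C@H]2CCC(=O)N2CCSCCCC(=O)O)c1` gives 5.7 nM, compound 2 `O=C(O)CCCSCCN1C(=O)CC[C@@H]1/C=C/[C@@H](O)Cc1cccc(-c2cc3ccccc3o2)c1` gives 7 nM, and compound 3 `O=C(O)c1csc(SCCN2C(=O)CC[C@@H]2/C=C/[C@@H](O)Cc2cccc(-c3ccccc3)c2)n1` gives 8 nM. Among the compounds with values here, the only single-point change among them, a 1.2-fold higher number from compound 1 to compound 2 (0.09 log units; within the scatter), changed nothing beyond the usual scatter. Compound 3 holds the largest of the three numbers, yet its gaps to compound 2 and compound 1 both fall within that scatter, so no real separation is indicated.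

Compound 4 `Cc1cccc2oc(-c3cccc(C[C@H](O)/C=C/[C@H]4CCC(=O)N4CCSc4nc(C(=O)O)cs4)c3)nc12` differs from compound 3 in one place: 4-methyl-1,3-benzoxazol-2-yl in place of phenyl on an aromatic carbon. Within the data shown here, the one measured step that bears on this, a 1.2-fold higher number from compound 1 to compound 2 (0.09 log units; within the scatter), also placed a larger aromatic group on an aromatic carbon of the same core and left the number essentially unchanged. Accordingly, no step beyond the scatter is expected in this assay ; compound 4 is estimated at 7 nM, within 2.5 nM to 20 nM, meaning an expected 1.1-fold lower number from compound 3 to compound 4 (0.06 log units; within the scatter).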

Compound 4, half-maximal effective concentration: 28 nM
Compound 4: the middle estimate sits 4.0-fold (0.60 log units) below what was measured, and the stated range ends below it.
By their numbers in this assay, from the lowest: compounds 1, 2 and 3 (each within the scatter of the next); then compound 4.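

Placing 4-methyl-1,3-benzoxazol-2-yl in place of phenyl gives a 3.5-fold higher number from compound 3 to compound 4 (0.54 log units; beyond the scatter) in this assay. Within the data shown here, this is the first step beyond the scatter at this place, meta to a large group, so the number here can depend on which two-ring aromatic group is attached, a dependence the earlier step within the scatter did not reveal. Nothing shown gives a reason for this step. Still open, on these data alone, is whether the methyl or the two-ring group itself accounts for the step; the plain 1,3-benzoxazol-2-yl group on the core of compound 3 would separate the two.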